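A few compounds are considered here, and "the series" means these few. Any claim that something is new, unique, unknown or untested is made for them only; others in the source may bear on it.

Measured so far:
- compound 1 `Cc1cc(C)cc(S(=O)(=O)c2c(C(=O)N[C@H]3CCNC3)[nH]c3ccc(Cl)cc23)c1`: 10000 nM
- compound 2 `Cc1cc(C)cc(S(=O)(=O)c2c(C(=O)N[C@@H]3CCN(Cc4n[nH]c(=O)n4C)C3)[nH]c3ccc(Cl)cc23)c1`: 22400 nM
- compound 3 `Cc1cc(C)cc(S(=O)(=O)c2c(C(=O)N[C@@H]3CCN(Cc4ccccc4F)C3)[nH]c3ccc(Cl)cc23)c1`: > 231000 nM (a limit of the assay)

In an ADME assay on MT4 cells (Homo sapiens) for cytotoxicity, read by MTT assay, with a stated time of 5 days (on this read-out lower numbers stand for higher toxicity in this test and higher numbers for lower toxicity in this test), compound 1 gives 10000 nM, the lower of the two true numbers; compound 2 gives 22400 nM. Compound 3 sits at a limit, (the limit of > 231000 nM in this assay, at which 1 of the 3 values shown sits).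

Compound 4 `Cc1cc(C)cc(S(=O)(=O)c2c(C(=O)N[C@@H]3CCN(S(C)(=O)=O)C3)[nH]c3ccc(Cl)cc23)c1` differs from compound 1 as follows: 1-(methylsulfonyl)pyrrolidin-3-yl in place of pyrrolidin-3-yl on an amide-type nitrogen.

Among the compounds with values here, the only measured step, an at least 10-fold higher number from compound 2 to compound 3 (1.01 log units; beyond the scatter), is large, but it exchanges one group for another on a saturated chain carbon, so it bears on this change only indirectly. A moderate rise towards lower toxicity in this test is expected, with wide uncertainty. The expected step is a 5.0-fold higher number from compound 1 to compound 4 (0.70 log units; beyond the scatter). For compound 4 the estimate is 50000 nM, with an expected range of 15000 nM to 230000 nM.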

Compound 4, half-maximal cytotoxic concentration: 24000 nM
The estimate for compound 4 lay 2.1-fold (0.32 log units) above the measured number; measured number inside the range.
By their numbers in this assay, from the lowest: compound 1; then compounds 2 and 4 (each within the scatter of the next). At a limit, above all of these: compound 3.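

In this assay, within the data shown here, methylsulfonyl on the amine nitrogen in a ring gives a 2.4-fold higher number from compound 1 to compound 4 (0.38 log units; beyond the scatter), a first direct reading of substitution there against the free pyrrolidin-3-yl compound. Two quite different substituents need not separate at this position: a 1.1-fold higher number from compound 2 to compound 4 (0.03 log units; within the scatter). Only the 2-fluorobenzyl group stands apart, with an at least 9.6-fold lower number from compound 3 to compound 4 (0.98 log units; beyond the scatter), and that step is only a bound, since compound 3 sits at a limit of the assay: the limit of > 231000 nM in this assay, at which 1 of the 4 values shown sits.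

Open, on these data alone, is whether an acetyl group or a longer alkyl chain on this nitrogen would stay with compound 4 or move towards compound 3. Also open, as far as these compounds go, is whether plain benzyl would match 2-fluorobenzyl.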